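Growing a Methyl to an Ethyl on the Shared Core

The source may hold more compounds than are shown below. What is called first, only, known or untested is meant among the compounds shown, and "the series" means these compounds.

Among the measured compounds shown here, in an ADME assay on HEL cells (Homo sapiens) for cytotoxicity, with a stated time of 3 days (a lower number here means that less compound is tolerated, a higher number that more compound is tolerated), compound 3 `CC1(Cc2ccccc2)OS(=O)(=O)C=C1OCc1ccccc1` gives 68000 nM, the only plain number among the three results so far. Compound 1 `CCC1(Cc2ccccc2)OS(=O)(=O)C=C1OCC(=O)OC` reaches only the limit of the assay, > 200000 nM. Compound 2 `CCC1(Cc2ccccc2)OS(=O)(=O)C=C1OCc1ccc(Cl)cc1` likewise sits at the limit, > 200000 nM. Between them lies a step that the two limits leave unreadable from compound 1 to compound 2, so no measured step bears on the change ahead. Compound 4 `CCC1(Cc2ccccc2)OS(=O)(=O)C=C1OCc1ccccc1` differs from compound 3 by methyl in place of hydrogen on a saturated chain carbon bound to a saturated ring carbon. Given the limit of > 200000 nM in this assay, at which 2 of the 3 values shown sit, the existing comparisons offer no direction at all, and a change of a single carbon is expected to stay within the scatter, so the estimate reads a 1.3-fold higher number from compound 3 to compound 4 (0.12 log units; within the scatter). Compound 4 is therefore expected to give 90000 nM, within a range from 35000 nM to 200000 nM.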

Compound 4, half-maximal cytotoxic concentration: 200000 nM
The estimate for compound 4 lay 2.2-fold (0.35 log units) below the measured number, within the range that was stated.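

On the saturated chain carbon bound to a saturated ring carbon, methyl in place of hydrogen changes the number: in this assay the step reads a 2.9-fold higher number from compound 3 to compound 4 (0.47 log units; beyond the scatter) and is the first readable step among these compounds. At this place, then, going from methyl to ethyl moves the number towards more compound tolerated. Hydrogen in place of chloro on an aromatic carbon gives a number no higher from compound 2 to compound 4 (the limit leaves the size open) and phenyl in place of methoxycarbonyl on a saturated chain carbon bound to an oxygen on an unsaturated carbon gives a number no higher from compound 1 to compound 4 (the limit leaves the size open) and the size of both steps cannot be read: the limit of > 200000 nM in this assay, at which 2 of the 4 values shown sit.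

This direction rests on a single pair of compounds. On these data alone, whether a longer chain, such as propyl, or an amine at this place would give a similar number remains open.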